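The source may report more compounds than this note shows. Statements on the series, on what has been measured and on what is new or still open speak of the compounds shown alone.

Measured so far in a functional assay on PC-3 cells (Homo sapiens) for cytotoxicity, read by MTT assay, with a stated time of 48 h; on this read-out lower numbers stand for stronger inhibition and higher numbers for weaker inhibition:
Compound 1 `N#Cc1ccc(Cn2c(/C=C3\SC(=S)N(CC(=O)O)C3=O)nc3ccccc32)cc1`: 14400 nM
Compound 2 `Cc1ccc(Cn2c(/C=C3\SC(=S)N(CC(=O)O)C3=O)nc3ccccc32)cc1`: 2640 nM

Of these two, compound 2 stands lowest in this assay at 2640 nM as measured, and compound 1 lies higher. Compound 3 `O=C(O)CN1C(=O)/C(=C/c2nc3ccccc3n2Cc2cccc(F)c2)SC1=S` has not yet been measured. Its difference from compound 2 is 3-fluorophenyl in place of 4-methylphenyl on a saturated chain carbon bound to an aromatic nitrogen in short, 3-fluorophenyl in place of 4-methylphenyl on a saturated chain carbon bound to an aromatic nitrogen. Within the data shown here, the one measured step that bears on this is a 5.5-fold lower number from compound 1 to compound 2 (0.74 log units; beyond the scatter) as methyl replaces cyano on an aromatic carbon, which also alters the 4-methylphenyl group of compound 2. Among the measured compounds shown here, no measured compound carries fluorine, so that step offers only a rough scale. A modest step of similar or smaller size is expected, toward a higher number, since compound 2 at 2640 nM is the lower of just two values. The expected change is a 1.7-fold higher number from compound 2 to compound 3 (0.23 log units; within the scatter) by this estimate. For compound 3 the estimated value is 4500 nM with an expected range from 1500 nM to 13000 nM in this assay.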

Compound 3, half-maximal inhibitory concentration: 35700 nM
Beside the measured number, compound 3's estimate is 7.9-fold (0.90 log units) below it; measured number outside the range, above it.
By their numbers in this assay, from the lowest: compound 2; then compound 1; then compound 3.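

In this assay, the group on the saturated chain carbon bound to an aromatic nitrogen can shift the number much further than the earlier pair showed: 3-fluorophenyl in place of 4-methylphenyl gives a 14-fold higher number from compound 2 to compound 3 (1.13 log units; beyond the scatter), the largest step seen here. Against 4-cyanophenyl the same 3-fluorophenyl group also raises the number, with a 2.5-fold higher number from compound 1 to compound 3 (0.39 log units; beyond the scatter), so compound 3 is the weakest of the three, and the step from the cyano compound shows that the loss is not confined to the comparison with the methyl compound. No supporting data on these groups are available to account for this order.

On these data alone, whether the rise follows from the fluorine itself or from where it sits on the ring stays open, and a 4-fluorophenyl or 3-methylphenyl group at this position would separate the two. Also open, as far as these compounds go, is whether a 4-methoxyphenyl or 4-chlorophenyl group would give a lower number than compound 2 at 2640 nM.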